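A few compounds are considered here, and "the series" means these few. Any claim that something is new, unique, unknown or untested is made for them only; others in the source may bear on it.

Measured in a functional assay on HeLa cells (Homo sapiens) for antiproliferative activity, read by CCK-8 assay, with a stated time of 72 h, tested at 8 uM; a lower number here means a weaker effect, a higher number a stronger effect of the compound at the concentration tested:
compound 1, `Nc1ccccc1NC(=O)c1ccc(CSC(=S)N2CCN(C(c3ccccc3)c3ccccc3)CC2)cc1`: 13.8%
compound 2, `Nc1ccccc1NC(=O)c1ccc(CSC(=S)N2CCN(c3ccccc3)CC2)cc1`: 73.1%
compound 3, `CN1CCN(C(=S)SCc2ccc(C(=O)Nc3ccccc3N)cc2)CC1`: 75.7%

Compound 3 has the highest of the three numbers in this assay, but its nearest neighbour, compound 2, sits within the scatter of it, so the two cannot be ordered; only compound 1 lies clearly beyond the scatter, far below both. Among the measured compounds shown here, the one step that can be read between measured compounds is a number 2.6 percentage points higher from compound 2 to compound 3 (within the scatter), which shows that swapping a phenyl for a methyl on the ring nitrogen leaves the read-out essentially unchanged.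

Compound 4, `Nc1ccccc1NC(=O)c1ccc(CSC(=S)N2CCN(Cc3ccccc3)CC2)cc1`, is not yet measured. It differs from compound 3 by phenyl in place of hydrogen on a saturated chain carbon bound to an amine nitrogen in a ring. For the measured compounds named here, no measured step matches this change exactly. The step from compound 2 to compound 3 bears on it only loosely, and it was flat. Compound 1, which carries the bulkiest group on that nitrogen, gives a much lower number than compound 2 or compound 3, which counsels some caution about growth at this position.

Compound 4 is therefore expected to give about 58% in this assay, a step of a number 17.7 percentage points lower from compound 3 to compound 4 (beyond the scatter), with a range from 30% to 80%.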

Compound 4, a percentage reported as inhibition, at one concentration (the size of the read-out at that concentration, not a potency): 31.3%
Compound 4: the middle estimate sits 26.7 percentage points above what was measured; the range from low to high includes it.
By their numbers in this assay, from the lowest: compound 1; then compound 4; then compounds 2 and 3 (each within the scatter of the next).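

In this assay the carbon bound to the ring nitrogen proves to be a sensitive place: adding a phenyl there gives a number 44.4 percentage points lower from compound 3 to compound 4 (beyond the scatter), whereas the earlier swap of methyl for phenyl directly on that nitrogen had shown no separable change. Compound 2 therefore goes against any reading that a phenyl in this part of the molecule lowers the number by itself, since moving to benzyl gives a number 41.8 percentage points lower from compound 2 to compound 4 (beyond the scatter), a drop seen only once the phenyl is carried on the saturated chain carbon. Removing one phenyl from the carbon that carries two in compound 1 gives a number 17.5 percentage points higher from compound 1 to compound 4 (beyond the scatter), so the number recovers only part of the way, and nothing measured on these compounds accounts for any of these steps.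

The compounds shown leave open whether a longer chain, such as phenethyl, or a non-aromatic group on the same carbon, such as cyclohexyl, would follow benzyl or return towards methyl. They also leave open whether a hydroxyl or methoxy group on the benzyl ring would change the read-out.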